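Aryl piperazine variant in a dithiocarbamate benzamide series

The source may hold more compounds than are shown below. What is called first, only, known or untested is meant among the compounds shown, and "the series" means these compounds.

Compound 1, `Nc1ccccc1NC(=O)c1ccc(CSC(=S)N2CCN(Cc3ccccn3)CC2)cc1`: 20.7%
Compound 2, `Nc1ccccc1NC(=O)c1ccc(CSC(=S)N2CCN(C(c3ccccc3)c3ccccc3)CC2)cc1`: 8.7%
Compound 3, `CN(C(=S)SCc1ccc(C(=O)Nc2ccccc2N)cc1)c1cccnc1`: 26.5%

All three were tested in a functional assay on A-375 cells (Homo sapiens) for antiproliferative activity, read by CCK-8 assay, with a stated time of 72 h, tested at 2 uM; on this read-out lower numbers stand for a weaker effect and higher numbers for a stronger effect at the one concentration tested. Compound 1 gives 20.7%, the second highest of the three numbers; compound 3 gives 26.5%, within the scatter of compound 1, whereas compound 2 gives 8.7%, beyond the scatter and lower. Compound 4, `COc1ccc(N2CCN(C(=S)SCc3ccc(C(=O)Nc4ccccc4N)cc3)CC2)cc1`, awaits measurement. It differs from compound 1 in one place: 4-methoxyphenyl in place of (pyridin-2-yl)methyl on an amine nitrogen in a ring. Going by the values given here, no measured pair in this set differs in a single place, so no comparable step is available. Compound 1 and compound 3 lie within the scatter of each other, and the step in this assay is expected to be small, with no clear direction beyond the scatter. Compound 4 is accordingly estimated at 20%, with a range from 6% to 36%, an expected step of a number 0.7 percentage points lower from compound 1 to compound 4 (within the scatter).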

Compound 4, a percentage reported as inhibition, at one concentration (the size of the read-out at that concentration, not a potency): 28.1%
Compound 4: the middle estimate sits 8.1 percentage points below what was measured; measured number inside the range.
By their numbers in this assay, from the lowest: compound 2; then compounds 1, 3 and 4 (each within the scatter of the next).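

In this assay, placing 4-methoxyphenyl instead of (pyridin-2-yl)methyl on the amine nitrogen in the ring gives a number 7.4 percentage points higher from compound 1 to compound 4 (within the scatter). At this position, therefore, the read-out does not separate the two groups, even though the entering ring is of carbon only and the leaving ring holds a hetero atom. No measurement of any property of these groups bears on this step. The compounds shown leave open how a benzyl group, or a methyl group, would read on this nitrogen.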